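Shortening the methoxy-terminated chain in the series

This account rests on a few compounds, and the source may have more. Where it says the series, first, only, none or still open, it means among the compounds named here.

Compound 2 `COCCCCCCCCCCCCCCC/C=C1\CC(CO)(COC(=O)C(C)(C)C)OC1=O` is the reference point. Within the data shown here, in a functional assay on K562 cells (Homo sapiens) for antiproliferative activity (a higher number here means a weaker inhibitor of growth, a lower number a stronger inhibitor of growth), compound 2 gives 0.189 ug/mL, the lowest of the three numbers so far. Compound 1 `CC(C)(C)C(=O)OCC1(CO)C/C(=C\CCCCCCCCCCCO)C(=O)O1` gives 1.09 ug/mL and compound 3 `CC(C)(C)C(=O)OCC1(CO)C/C(=C/CCCCCCCCCCCCCCC=O)C(=O)O1` gives 2.58 ug/mL, both beyond the scatter from compound 2. Among the measured compounds shown here, the one measured step, a 5.8-fold lower number from compound 1 to compound 2 (0.76 log units; beyond the scatter), is the only change so far on this chain, and it alters both the end group and the chain length at once.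

Compound 4 `COCCCCCCCCCCC/C=C1\CC(CO)(COC(=O)C(C)(C)C)OC1=O` differs from compound 2 as follows: methoxy in place of 4-methoxybutyl on a saturated chain carbon, ten or more bonds along the chain from a double-bonded chain carbon. For the measured compounds named here, no measured step isolates chain length alone. Compound 1, with a chain of the length now reached and a hydroxy end, sits some way above compound 2 in this assay, so a shorter chain is expected to cost something while the methoxy end is expected to hold part of the gain. The expected step is a 2.4-fold higher number from compound 2 to compound 4 (0.38 log units; beyond the scatter), a modest rise. Compound 4 is therefore estimated at 0.45 ug/mL, with a range from 0.15 ug/mL to 1.3 ug/mL.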

Compound 4, concentration for 50% growth inhibition: 0.516 ug/mL
The estimate for compound 4 lay 1.1-fold (0.06 log units) below the measured number, within the range that was stated.
By their numbers in this assay, from the lowest: compound 2; then compound 4; then compound 1; then compound 3.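

In this assay the earlier step mixed end group and chain length, and compound 4 now lets the two be read apart. With the methoxy end held, going to the shorter chain, methoxy in place of 4-methoxybutyl, gives a 2.7-fold higher number from compound 2 to compound 4 (0.44 log units; beyond the scatter) and not a flat result, so chain length matters in its own right at this position. At the shorter length, methyl in place of hydrogen on the end oxygen gives a 2.1-fold lower number from compound 1 to compound 4 (0.32 log units; beyond the scatter) as a second change beyond the scatter, and no evidence at hand explains either step.

Going by these compounds, whether a chain longer than that of compound 2 lowers the number further remains open. Also open, on these data alone, is how an ethoxy group, an amine or a carboxylic acid at the chain end would compare with methoxy.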